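Trimming the Amide Arm of Compound 2

This account rests on a few compounds, and the source may have more. Where it says the series, first, only, none or still open, it means among the compounds named here.

Going by the values given here, compound 2 `COc1cc(-c2nn(-c3cccc(NC(=O)Nc4cccc(C(F)(F)F)c4)c3)cc2-c2ccncc2)ccc1Cl` gives 3430 nM in a functional assay on COLO 205 cells (Homo sapiens) for inhibition, read by sulforhodamine B assay, with a stated time of 48 h (a higher number here means that more compound is tolerated, a lower number that less compound is tolerated), the highest of the two numbers so far; compound 1 `COc1cc(-c2nn(-c3cccc(NC(=O)Nc4cc(C(F)(F)F)cc(C(F)(F)F)c4)c3)cc2-c2ccncc2)ccc1Cl` gives 2910 nM, and the step of a 1.2-fold higher number from compound 1 to compound 2 (0.07 log units; within the scatter) lies within the scatter. Compound 3 `COc1cc(-c2nn(-c3cccc(NC(=O)c4ccccc4)c3)cc2-c2ccncc2)ccc1Cl` differs from compound 2 by phenyl in place of (3-(trifluoromethyl)phenyl)amino on a carbonyl carbon. Among the compounds with values here, the single measured step, a 1.2-fold higher number from compound 1 to compound 2 (0.07 log units; within the scatter), stayed within the scatter when only a trifluoromethyl was removed, but the present change is larger and reaches the amide-type nitrogen, so a modest rise is expected, as a 1.6-fold higher number from compound 2 to compound 3 (0.21 log units; within the scatter). Compound 3 is estimated at 5500 nM, with a range from 2000 nM to 15000 nM.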

Compound 3, concentration lethal to 50% of the cells: 68400 nM
Compound 3: middle estimate off by 12-fold (1.09 log units), on the low side; the whole stated range lies below it.
By their numbers in this assay, from the lowest: compounds 1 and 2 (each within the scatter of the next); then compound 3.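

Setting phenyl in place of (3-(trifluoromethyl)phenyl)amino on the carbonyl carbon gives a 20-fold higher number from compound 2 to compound 3 (1.30 log units; beyond the scatter) in this assay, whereas removing one trifluoromethyl gave only a 1.2-fold higher number from compound 1 to compound 2 (0.07 log units; within the scatter). This position therefore tolerates the loss of one trifluoromethyl with no change beyond the scatter, but not the replacement of the whole arm. Nothing available explains the rise.

The change removes the amino link and the remaining trifluoromethyl together, so the compounds shown cannot separate their contributions. A plain phenylamino group on the same carbonyl carbon would help to separate them.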